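The compounds below may be only part of what the source reports. "The series", "measured", "known", "first", "only" and "open" are said of these compounds alone.

The compounds measured in an ADME assay on HEK293 cells (Homo sapiens) for cytotoxicity, read by sulforhodamine B assay, with a stated time of 48 h, tested at 10 uM (a lower number here means less inhibition, a higher number more inhibition at the concentration tested (going by the name of the read-out)), are:
compound 1, `CCCCCCCc1cn(C(c2ccccc2)c2cc3cc(Br)ccc3nc2OC)nn1`, 0.17%;
compound 2, `CCOC(=O)c1cn(C(c2ccccc2)c2cc3cc(Br)ccc3nc2OC)nn1`, 2%;
compound 3, `COc1nc2ccc(Br)cc2cc1C(c1ccccc1)n1cc(CO)nn1`, 11.5%.

Compound 3 holds the highest of the three numbers shown. Its nearest neighbour is compound 2, and a number 9.5 percentage points higher from compound 2 to compound 3 (within the scatter) lies within the scatter, so the two cannot be ordered against each other. The gap to compound 1 is wider: a number 11.3 percentage points higher from compound 1 to compound 3 (beyond the scatter) lies beyond the scatter, though it remains modest. Between the other two, a number 1.8 percentage points higher from compound 1 to compound 2 (within the scatter) is also within the scatter.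

Compound 4, `COc1nc2ccc(Br)cc2cc1C(c1ccccc1)n1cc(C2CC2)nn1`, has not yet been measured. It differs from compound 3 in one place: cyclopropyl in place of hydroxymethyl on an aromatic carbon. Among the compounds with values here, the steps that bear on this change are the two that brought the hydroxy group onto the shared core, a number 11.3 percentage points higher from compound 1 to compound 3 (beyond the scatter) and a number 9.5 percentage points higher from compound 2 to compound 3 (within the scatter); both moved the number upward, one of them beyond the scatter. Compound 4 carries no hydrogen-bond donor and no hydrogen-bond acceptor at that carbon, so the step is expected to run the other way, back toward the numbers of compound 1 and compound 2. For compound 4 in this assay the expected step is a number 8 percentage points lower from compound 3 to compound 4 (within the scatter). Compound 4 is therefore estimated to give 3.5%, within a range from 0% to 12%.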

Compound 4, a percentage reported as inhibition, at one concentration (the size of the read-out at that concentration, not a potency): 8.22%
For compound 4 the middle estimate is 4.7 percentage points below the measured one; low and high end bracket the measured number.
By their numbers in this assay, from the lowest: compounds 1, 2, 4 and 3 (each within the scatter of the next, the first and the last beyond it).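

In this assay, putting cyclopropyl in place of hydroxymethyl on this aromatic carbon of the five-membered ring gives a number 3.3 percentage points lower from compound 3 to compound 4 (within the scatter) and so removes a hydrogen-bond donor and a hydrogen-bond acceptor from the position with no step beyond the scatter. Within the data shown here, compound 4 also cannot be separated from the compounds with the other two groups at this carbon, with a number 6.2 percentage points higher from compound 2 to compound 4 (within the scatter) on the change from ethoxycarbonyl and a number 8.1 percentage points higher from compound 1 to compound 4 (within the scatter) on the change from heptyl, so it stands within the scatter of compound 1 and compound 3, the one pair printed as lying beyond it; the earlier compounds left open whether a group without the hydroxy could stay within the scatter of compound 3, and compound 4 shows that cyclopropyl does. No measurement shown here offers an explanation for these numbers.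

What the compounds shown leave open is whether an amine, a carboxylic acid or a phenyl ring at this same carbon would stand beyond the scatter from compound 3. They also leave open how far any of these numbers would carry to other concentrations or other cell lines, since every one comes from a single concentration on one cell line.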